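The source may report more compounds than this note shows. Statements on the series, on what has been measured and on what is new or still open speak of the compounds shown alone.

Within the data shown here, in a functional assay on RAW264.7 cells (Mus musculus), read by ELISA, with a stated time of 24 h (a higher number here means that more compound is needed for the effect, a lower number that less compound is needed), only two compounds have numbers so far. Compound 1 `CCOC(=O)CC[C@@H]1NCCc2cc(O)c(O)cc21` gives 18000 nM, and compound 2 `OCc1ccc(C2=NCCc3cc(O)c(O)cc32)o1` gives 18000 nM. Compound 2 therefore stands level with compound 1, and the two readings show no difference beyond the usual scatter of this kind of measurement.

Compound 3 `Oc1cc2c(cc1O)C(c1ccco1)=NCC2` has not yet been measured. It differs from compound 2 in one place, (hydrogen in place of hydroxymethyl on an aromatic carbon), with hydrogen in place of hydroxymethyl on an aromatic carbon. Among the measured compounds shown here, no measured pair isolates this change, so the data offer no direct guide to its size or direction.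

The only available clue is indirect: compound 2 at 18000 nM matches compound 1 at 18000 nM, even though the two structures are clearly different. On that limited basis, no step beyond the scatter is expected in this assay, in either direction, and the estimated change is a 1.1-fold higher number from compound 2 to compound 3 (0.05 log units; within the scatter). For compound 3, the expected value is 20000 nM, with an estimated range of 8000 nM to 50000 nM.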

Compound 3, half-maximal effective concentration: 18000 nM
Compound 3: the middle estimate sits 1.1-fold (0.05 log units) above what was measured; the measured number falls inside the stated range.
By their numbers in this assay, from the lowest: compounds 1, 2 and 3 (each within the scatter of the next).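

In this assay, putting hydrogen in place of hydroxymethyl on the aromatic carbon next to the ring oxygen of the five-membered aromatic ring gives no change at the digits printed from compound 2 to compound 3 (within the scatter). Compound 1 and compound 2 differ in more than one place, so they said nothing about this position, whereas this pair isolates it: hydroxymethyl, with its 2 heavy atoms, 1 hydrogen-bond donor and 1 hydrogen-bond acceptor, can give way to a single hydrogen atom with no step beyond the scatter in this read-out. Nothing measured alongside these compounds offers an account of this result.

What the compounds shown leave open is whether this position tolerates any group, since only hydroxymethyl and hydrogen appear there, and an amine, a carboxylic acid or a longer chain on the same aromatic carbon could give a different reading. They also leave open whether the same swap would give a similar result on a different core, as this single pair speaks only for the core shared by compound 2 and compound 3.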